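The source may report more compounds than this note shows. Statements on the series, on what has been measured and on what is new or still open speak of the compounds shown alone.

Compound 1, `Cc1ccccc1NC(=O)NCC1(c2ccccc2)CCCCC1`, gives 640 nM in an assay on microsomes from intestine for inhibition of acyl-CoA:cholesterol acyltransferase (Oryctolagus cuniculus); on this read-out higher numbers stand for weaker inhibition and lower numbers for stronger inhibition. Compound 2, `O=C(NCC1(c2ccccc2)CCCCC1)Nc1ccc(Cl)cc1`, gives 2200 nM in this assay. Compound 3, `O=C(NCC1(c2ccccc2)CCCCC1)Nc1ccc(I)cc1`, gives 2300 nM in this assay.

Compound 3 stands at the highest of the three numbers. Against compound 2 the difference is a 1.0-fold higher number from compound 2 to compound 3 (0.02 log units; within the scatter), so the two lie within the scatter of each other; against compound 1 the difference is a 3.6-fold higher number from compound 1 to compound 3 (0.56 log units; beyond the scatter), which is beyond the scatter.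

Compound 4, `O=C(NCC1(c2ccccc2)CCCCC1)Nc1ccc(Cl)c(Cl)c1`, differs from compound 3 in one place: 3,4-dichlorophenyl in place of 4-iodophenyl on an amide-type nitrogen. For the measured compounds named here, two measured steps bear on this change. The step of a 1.0-fold higher number from compound 2 to compound 3 (0.02 log units; within the scatter) shows that exchanging one halogen for another at this position left the number essentially unchanged. The steps of a 3.4-fold higher number from compound 1 to compound 2 (0.54 log units; beyond the scatter) and a 3.6-fold higher number from compound 1 to compound 3 (0.56 log units; beyond the scatter) show that both halogen-bearing phenyl groups sat at modestly higher numbers than the 2-methylphenyl of compound 1. No measured step covers the addition of a second chlorine, so nothing among these compounds shows how that addition shifts the number.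

On this basis compound 4 is expected to stay close to compound 3 in this assay, with a step of about a 1.2-fold lower number from compound 3 to compound 4 (0.06 log units; within the scatter), not clearly beyond the scatter in either direction. The estimate for compound 4 is therefore 2000 nM, with a range from 700 nM to 6000 nM.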

Compound 4, half-maximal inhibitory concentration: 3800 nM
Compound 4: middle estimate off by 1.9-fold (0.28 log units), on the low side; measured number inside the range.
By their numbers in this assay, from the lowest: compound 1; then compounds 2, 3 and 4 (each within the scatter of the next).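

For the compounds shown here, the new compound gives the first reading of a second chlorine on the ring: in this assay the addition appears as a 1.7-fold higher number from compound 2 to compound 4 (0.24 log units; within the scatter) and so does not separate compound 4 from the singly chlorinated compound 2. Exchanging 4-iodophenyl for 3,4-dichlorophenyl on the amide-type nitrogen likewise appears as a 1.7-fold higher number from compound 3 to compound 4 (0.22 log units; within the scatter) and leaves these two compounds inseparable, while the comparison with the 2-methylphenyl group gives a 5.9-fold higher number from compound 1 to compound 4 (0.77 log units; beyond the scatter) and places a third halogen-bearing phenyl group clearly apart from compound 1. Nothing among the data explains any of these steps.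

Compound 1 differs from compounds 2, 3 and 4 both in its group and in where that group sits on the phenyl ring, so the compounds shown cannot tell these two influences apart. Going by these compounds, how a methoxy group, an amine or a carboxylic acid on this phenyl ring would read in this assay also stays open, as does any change to the shared core, which is the same in all four compounds.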